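This account rests on a few compounds, and the source may have more. Where it says the series, first, only, none or still open, it means among the compounds named here.

Series notes. The shared core is the same throughout; the variation sits on the aryl ring on the sulfonamide nitrogen. Within the data shown here, compound 1 `O=S(=O)(Nc1ccc(F)c(Cl)c1)c1ccc(-c2cnc(C3CC3)o2)cc1` gives 260 nM in a functional assay on cells (leukaemia cell line, Homo sapiens) for inhibition, read by sulforhodamine B assay, with a stated time of 48 h (on this read-out higher numbers stand for weaker inhibition of growth and lower numbers for stronger inhibition of growth), the lowest of the three numbers measured so far. Compound 2 `O=S(=O)(Nc1ccc(Br)c(Cl)c1)c1ccc(-c2cnc(C3CC3)o2)cc1` gives 491 nM in this assay; the step of a 1.9-fold higher number from compound 1 to compound 2 (0.28 log units; within the scatter) stays within the scatter, so compound 1 and compound 2 cannot be ordered against each other. Compound 3 `O=S(=O)(Nc1cc(Cl)ccc1Cl)c1ccc(-c2cnc(C3CC3)o2)cc1` gives 1020 nM in this assay, and the steps of a 3.9-fold higher number from compound 1 to compound 3 (0.59 log units; beyond the scatter) and a 2.1-fold higher number from compound 2 to compound 3 (0.32 log units; beyond the scatter) both lie beyond the scatter, both modest.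

Compound 4 `O=S(=O)(Nc1ccc(I)c(Cl)c1)c1ccc(-c2cnc(C3CC3)o2)cc1` is not yet measured. It differs from compound 1 by iodo in place of fluoro on an aromatic carbon. Among the measured compounds shown here, the only measured step that bears on this change is a 1.9-fold higher number from compound 1 to compound 2 (0.28 log units; within the scatter), a swap of fluoro for bromo at the same aromatic carbon, which stayed within the scatter. No halogen beyond bromo has been measured at that carbon, so the expectation rests on that single step: a number for compound 4 near that of compound 1 or somewhat higher, with no step beyond the scatter firmly expected in this assay. Compound 4 is therefore estimated at 450 nM, within 200 nM to 1000 nM. The step this estimate implies is a 1.7-fold higher number from compound 1 to compound 4 (0.24 log units; within the scatter).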

Compound 4, concentration for 50% growth inhibition: 1010 nM
Compound 4: the middle estimate sits 2.2-fold (0.35 log units) below what was measured; measured number outside the range, above it.
By their numbers in this assay, from the lowest: compounds 1 and 2 (each within the scatter of the next); then compounds 4 and 3 (each within the scatter of the next).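

At the aromatic carbon para to a large group, the halogen now makes a difference in this assay: iodo in place of fluoro gives a 3.9-fold higher number from compound 1 to compound 4 (0.59 log units; beyond the scatter), a modest step, and iodo in place of bromo gives a 2.1-fold higher number from compound 2 to compound 4 (0.31 log units; beyond the scatter), also modest. The earlier step, a 1.9-fold higher number from compound 1 to compound 2 (0.28 log units; within the scatter), did not separate fluoro from bromo, so of the three halogens at this carbon only iodo stands apart from both others, and fluoro and bromo remain unordered. Against the earlier aryl variation, a 1.0-fold lower number from compound 3 to compound 4 (0.00 log units; within the scatter) stays within the scatter, so the 3-chloro-4-iodophenyl and 2,5-dichlorophenyl groups cannot be ordered in this assay, although they differ in how the ring is substituted.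

The compounds shown leave open how this carbon responds to a group other than a halogen, such as methoxy, nitrile, an amine or a carboxylic acid, and whether the iodo result holds without the chloro group on the same ring. Nothing given here bears on why iodo differs from the two lighter halogens at this carbon.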